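Removing the ring methoxy: compound 3 to compound 4

The compounds below may be only part of what the source reports. "The series", "measured", "known", "first", "only" and "open" are said of these compounds alone.

Among the compounds with values here, compound 3 `COc1ccc2c(c1)[n+]([O-])nc(NCOCc1ccccc1)[n+]2[O-]` gives 2400 nM in a functional assay on KB cells (Homo sapiens) for cytotoxicity, read by MTT assay, with a stated time of 72 h (a lower number here means a stronger inhibitor, a higher number a weaker inhibitor), the second highest of the three numbers so far. Compound 1 `CCCOCNc1n[n+]([O-])c2cc(OC)ccc2[n+]1[O-]` is nearest at 3200 nM, and the change between them, a 1.3-fold lower number from compound 1 to compound 3 (0.12 log units; within the scatter), stays within the scatter. Compound 2 `O=[N+]([O-])c1cccc(COCNc2n[n+]([O-])c3ccccc3[n+]2[O-])c1`, at 580 nM, sits furthest below and beyond the scatter. Within the data shown here, it differs from compound 3 in two places, so the pair shows only that a compound without the methoxy can give a lower number. Compound 4 `[O-][n+]1nc(NCOCc2ccccc2)[n+]([O-])c2ccccc21` carries the change (hydrogen in place of methoxy on an aromatic carbon). Among the measured compounds shown here, no measured step covers this change on its own. A modest lowering, or none beyond the scatter, is expected, a 1.6-fold lower number from compound 3 to compound 4 (0.20 log units; within the scatter). Compound 4 is therefore estimated at 1500 nM, between 600 nM and 3800 nM.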

Compound 4, half-maximal inhibitory concentration: 5720 nM
The estimate for compound 4 lay 3.8-fold (0.58 log units) below the measured number; measured number above the stated range.
By their numbers in this assay, from the lowest: compound 2; then compounds 3, 1 and 4 (each within the scatter of the next, the first and the last beyond it).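

Within the data shown here, replacing methoxy with hydrogen on this aromatic carbon gives the first measured step for this change (a 2.4-fold higher number from compound 3 to compound 4 (0.38 log units; beyond the scatter)), and it raises the number rather than lowering it. Hydrogen in place of nitro, on an aromatic carbon elsewhere in the molecule, also raises it (a 9.9-fold higher number from compound 2 to compound 4 (0.99 log units; beyond the scatter)). Among the compounds shown, compound 4, with neither group, therefore stands above both compound 3 and compound 2 by more than the scatter.

From the compounds shown here alone, whether an amine or a hydroxyl on the methoxy-bearing carbon would also give a lower number than hydrogen remains open, as does the outcome of carrying methoxy and nitro together. Nothing available explains either step.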